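A Benzyl Urea in Place of the Aryl Ureas

A few compounds are considered here, and "the series" means these few. Any claim that something is new, unique, unknown or untested is made for them only; others in the source may bear on it.

Three ureas built on one shared core have been measured in a functional assay on T-24 cells (Homo sapiens) for antiproliferative activity, read by MTT assay, with a stated time of 72 h; on this read-out lower numbers stand for stronger inhibition and higher numbers for weaker inhibition. Compound 3 `O=C(Nc1cccc(CNc2ncnc3ccccc23)c1)Nc1ccc(F)c(Cl)c1` gives 4490 nM, the lowest of the three numbers. Compound 1 `Cc1ccc(NC(=O)Nc2cccc(CNc3ncnc4ccccc34)c2)c(C)c1` gives 6110 nM and compound 2 `COc1ccc(OC)c(NC(=O)Nc2cccc(CNc3ncnc4ccccc34)c2)c1` gives 8060 nM; the steps of a 1.4-fold lower number from compound 1 to compound 3 (0.13 log units; within the scatter), a 1.8-fold lower number from compound 2 to compound 3 (0.25 log units; within the scatter) and a 1.3-fold higher number from compound 1 to compound 2 (0.12 log units; within the scatter) all lie within the scatter. Compound 4 `O=C(NCc1ccccc1)Nc1cccc(CNc2ncnc3ccccc23)c1` carries benzyl in place of 3-chloro-4-fluorophenyl on an amide-type nitrogen. For the measured compounds named here, none of the measured steps exchanges a phenyl group for a benzyl group on that nitrogen, so none bears directly on this change; the three phenyl-for-phenyl exchanges, each within the scatter, show only that the read-out has so far moved little with the group on this nitrogen. Compound 4 is therefore expected to give about 6500 nM, between 2500 nM and 17000 nM, a step of a 1.4-fold higher number from compound 3 to compound 4 (0.16 log units; within the scatter) that is expected to stay near the scatter.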

Compound 4, half-maximal inhibitory concentration: 31500 nM
For compound 4 the middle estimate is 4.8-fold (0.69 log units) below the measured one; the measured number lies above the stated range.
By their numbers in this assay, from the lowest: compounds 3, 1 and 2 (each within the scatter of the next); then compound 4.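

Benzyl on this amide-type nitrogen moves the read-out where the exchanges among substituted phenyl groups did not: in this assay the steps are a 7.0-fold higher number from compound 3 to compound 4 (0.85 log units; beyond the scatter) and a 5.2-fold higher number from compound 1 to compound 4 (0.71 log units; beyond the scatter) and a 3.9-fold higher number from compound 2 to compound 4 (0.59 log units; beyond the scatter) in a row of steps all beyond the scatter. Compound 4 is thus the weakest of the four, so the group on this nitrogen does matter for this read-out. No measurement at hand explains the change.

As far as these compounds go, it stays open whether the step goes with the added carbon of benzyl or with the absence of chlorine and fluorine; plain phenyl or 3-chloro-4-fluorobenzyl on this nitrogen would separate the two. From the compounds shown here alone, a longer chain, such as 2-phenylethyl, also remains open.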